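The compounds below may be only part of what the source reports. "The series", "measured", "known", "first", "only" and "open" are said of these compounds alone.

Measured so far:
Compound 1, `COc1ccc(-c2c3ccc4ccccc4c3nc3c2c(C)nc2c4ccccc4ccc32)cc1`: 66400 nM
Compound 2, `Cc1nc2c3ccccc3ccc2c2nc3c(ccc4ccccc43)c(-c3ccccc3S)c12`: 4070 nM

In a functional assay on AGS cells (Homo sapiens) for cytotoxicity, read by MTT assay, with a stated time of 48 h (a higher number here means a weaker inhibitor, a lower number a stronger inhibitor), compound 2 holds the lowest of the two numbers; its nearest neighbour is compound 1, which sits higher by the step of a 16-fold lower number from compound 1 to compound 2 (1.21 log units; beyond the scatter), a large step beyond the scatter. Compound 3, `Cc1nc2c3ccccc3ccc2c2nc3c(ccc4ccccc43)c(-c3ccc(O)cc3)c12`, is not yet measured. It differs from compound 2 in one place: 4-hydroxyphenyl in place of 2-sulfanylphenyl on an aromatic carbon. Going by the values given here, the only measured step that bears on this change is a 16-fold lower number from compound 1 to compound 2 (1.21 log units; beyond the scatter), in which 2-sulfanylphenyl displaced 4-methoxyphenyl and brought the large fall in the number. The 4-hydroxyphenyl of compound 3 resembles the 4-methoxyphenyl of compound 1 more closely than it resembles the 2-sulfanylphenyl of compound 2, so a move back toward the number of compound 1 is expected, though its full size is uncertain. Compound 3 is therefore estimated to give 25000 nM in this assay, within a range of 7000 nM to 90000 nM, an expected step of a 6.1-fold higher number from compound 2 to compound 3 (0.79 log units; beyond the scatter).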

Compound 3, half-maximal inhibitory concentration: 14200 nM
For compound 3 the middle estimate is 1.8-fold (0.25 log units) above the measured one; the range from low to high includes it.
By their numbers in this assay, from the lowest: compound 2; then compound 3; then compound 1.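

In this assay, 4-hydroxyphenyl in place of 2-sulfanylphenyl gives a 3.5-fold higher number from compound 2 to compound 3 (0.54 log units; beyond the scatter), while hydrogen in place of the methyl on the oxygen gives a 4.7-fold lower number from compound 1 to compound 3 (0.67 log units; beyond the scatter), so compound 3 lies between the other two and this aromatic carbon separates all three groups beyond the scatter. The second step shows that a change confined to the oxygen of the 4-methoxyphenyl is enough to move the number, whereas the first step changes both the atom and its place on the phenyl ring, so it cannot assign the difference to either one. Nothing measured here explains why either step takes this size.

As far as these compounds go, it remains open whether the gap follows sulfur or its place on the ring, a question that 2-hydroxyphenyl and 4-sulfanylphenyl could separate. Also open, from the compounds shown here alone, is how a phenyl ring carrying an amine or a carboxylic acid would behave at this carbon.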